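A few compounds are considered here, and "the series" means these few. Any claim that something is new, unique, unknown or untested is made for them only; others in the source may bear on it.

Measured compounds:
- compound 1 `COc1cc(C2Oc3cc([C@H]4Oc5cc(O)cc(O)c5C(=O)[C@@H]4O)ccc3OC2COC(=O)c2cccc(Cl)c2)ccc1O`: 106000 nM
- compound 2 `COc1cc(C2Oc3cc([C@H]4Oc5cc(O)cc(O)c5C(=O)[C@@H]4O)ccc3OC2COC(=O)c2ccc(OC)c(OC)c2)ccc1O`: 77000 nM

In a functional assay, read by spectrophotometry, with a stated time of 30 min (on this read-out higher numbers stand for an effect only at larger amounts of compound and lower numbers for an effect already at smaller amounts), compound 1 stands as the highest of the two numbers shown, and its nearest neighbour is compound 2, the gap being a 1.4-fold lower number from compound 1 to compound 2 (0.14 log units; within the scatter). That single step swaps the group on the carbonyl carbon of the ester and leaves the read-out within the scatter, so the two numbers cannot be ordered.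

Compound 3 `COc1cc(C2Oc3cc([C@H]4Oc5cc(O)cc(O)c5C(=O)[C@@H]4O)ccc3OC2COC(=O)/C=C/c2ccc(Br)cc2)ccc1O` is the next member. It differs from compound 1 by 2-(4-bromophenyl)ethenyl in place of 3-chlorophenyl on a carbonyl carbon. Within the data shown here, the only measured step that bears on this change is the one from compound 1 to compound 2, which also alters the group on the same carbonyl carbon and moves the number by a 1.4-fold lower number from compound 1 to compound 2 (0.14 log units; within the scatter), within the scatter. On that basis no step beyond the scatter is expected for compound 3 in this assay, in either direction. Compound 3 is therefore expected to sit near compound 1, with an expected step of a 1.2-fold lower number from compound 1 to compound 3 (0.07 log units; within the scatter). The estimate for compound 3 in this assay is 90000 nM, expected to fall between 40000 nM and 200000 nM.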

Compound 3, half-maximal effective concentration: 88900 nM
Beside the measured number, compound 3's estimate is 1.0-fold (0.01 log units) above it; measured number inside the range.
By their numbers in this assay, from the lowest: compounds 2, 3 and 1 (each within the scatter of the next).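

In this assay, the position on the carbonyl carbon now tolerates a change of a different kind from the earlier swap of one phenyl group for another: 2-(4-bromophenyl)ethenyl in place of 3-chlorophenyl brings in a double bond outside aromatic rings and a bromine, yet gives a 1.2-fold lower number from compound 1 to compound 3 (0.08 log units; within the scatter) on the read-out. Set against the 3,4-dimethoxyphenyl group, the same entering group gives a 1.2-fold higher number from compound 2 to compound 3 (0.06 log units; within the scatter), so the three groups shown on this carbonyl carbon cannot be ordered, and all the numbers stay within the scatter of one another. Nothing available on this series offers an explanation for that lack of separation.

From the compounds shown here alone, all three groups carry a six-membered aromatic ring of carbon only, so it remains open whether a group on the same carbonyl carbon without such a ring, such as a simple methyl, or one bearing an amine or a carboxylic acid, would move the number beyond the scatter. Going by these compounds, it is equally open whether a longer chain between the carbonyl and the ring, or a change elsewhere on the shared core, would do so.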